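Moving a Fluorine on an Amide Side Group

The source may hold more compounds than are shown below. What is called first, only, known or untested is meant among the compounds shown, and "the series" means these compounds.

Of the compounds shown here, two built around the same core have been tested in a functional assay on MCF7 cells (Homo sapiens) for antiproliferative activity, read by MTT assay, with a stated time of 72 h; on this read-out higher numbers stand for weaker inhibition and lower numbers for stronger inhibition. Compound 1, with structure `CCN1CCN(c2cc(C)c3cc(NC(=O)c4ccccc4F)ccc3n2)CC1`, gives 32600 nM. Compound 2, with structure `Cc1cc(N(C)C)nc2ccc(NC(=O)c3ccc(Cl)c(Cl)c3)cc12`, carries a different amine and a different acyl group on the shared core; in this assay compound 2 gives 33300 nM. These two numbers lie within the usual scatter of each other, so compound 1 cannot be placed ahead of or behind compound 2 on this read-out; both sit at weak inhibition.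

Compound 3, with structure `CCN1CCN(c2cc(C)c3cc(NC(=O)c4cccc(F)c4)ccc3n2)CC1`, differs from compound 1 in a single place: 3-fluorophenyl in place of 2-fluorophenyl on a carbonyl carbon. Going by the values given here, nothing else in the molecule changes, and no measured pair here shows what such a move of the fluorine does to the numbers. With only weak inhibition seen for compound 1 at 32600 nM, and no comparison to guide the direction, the step from compound 1 to compound 3 is expected to be small, likely within the scatter. For compound 3 the expected result in this assay is 30000 nM, with a plausible range from 10000 nM to 90000 nM, which means an expected step of a 1.1-fold lower number from compound 1 to compound 3 (0.04 log units; within the scatter).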

Compound 3, half-maximal inhibitory concentration: 8920 nM
The estimate for compound 3 lay 3.4-fold (0.53 log units) above the measured number; the whole stated range lies above it.
By their numbers in this assay, from the lowest: compound 3; then compounds 1 and 2 (each within the scatter of the next).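

Swapping 2-fluorophenyl for 3-fluorophenyl on a carbonyl carbon gives a 3.7-fold lower number from compound 1 to compound 3 (0.56 log units; beyond the scatter) in this assay, the first change in this series that can be read in one place alone. The two compounds hold the same atoms, joined differently, so this step shows that where the fluorine sits on this amide side group can matter on its own, with no atom added or removed, something the comparison of compound 1 with compound 2 could not show, as those two differ in more than one place. No measurement here bears on what lies behind this step.

The compounds shown leave open whether a plain phenyl group with no fluorine at all, or a 3-chlorophenyl or 3-methoxyphenyl group, on the same carbonyl carbon would give a number closer to that of compound 1 or of compound 3. They also leave open whether the same move of the fluorine would give a similar step with a different amine on the shared core, such as a morpholine in place of the ethylpiperazine.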